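Sulfamoylurea series: growing the amine on the sulfonyl sulfur

The source may report more compounds than this note shows. Statements on the series, on what has been measured and on what is new or still open speak of the compounds shown alone.

Compound 1 `CCN(CC)S(=O)(=O)NC(=O)Nc1c(C(C)C)cccc1C(C)C`: 2500 nM
Compound 2 `CCCCN(CC)S(=O)(=O)NC(=O)Nc1c(C(C)C)cccc1C(C)C`: 1200 nM

Going by the values given here, in an assay on liver for inhibition of sterol O-acyltransferase 1 (Rattus norvegicus), using microsomes (a lower number here means a stronger inhibitor, a higher number a weaker inhibitor), compound 2 holds the lower of the two numbers measured so far; its nearest neighbour is compound 1, and the only measured step is a 2.1-fold lower number from compound 1 to compound 2 (0.32 log units; beyond the scatter), a modest move beyond the scatter in which more chain carbon on the amine went with a lower number. Compound 3 `CC(C)CN(CC(C)C)S(=O)(=O)NC(=O)Nc1c(C(C)C)cccc1C(C)C` carries the same shared core and differs from compound 2 in one place: diisobutylamino in place of butyl(ethyl)amino on a sulfonyl sulfur. Among the compounds with values here, only the step from compound 1 to compound 2 bears on this change, and it points the same way, since compound 3 again adds carbon on the amine attached to the sulfonyl sulfur. A further modest step toward a lower number is therefore expected, with wide uncertainty because a single measured step is a thin basis. Compound 3 is estimated at 700 nM, within 250 nM to 2500 nM. The step to compound 3 expected here is a 1.7-fold lower number from compound 2 to compound 3 (0.23 log units; within the scatter).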

Compound 3, half-maximal inhibitory concentration: 420 nM
The estimate for compound 3 lay 1.7-fold (0.22 log units) above the measured number; low and high end bracket the measured number.
By their numbers in this assay, from the lowest: compound 3; then compound 2; then compound 1.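

In this assay, diisobutylamino in place of butyl(ethyl)amino on a sulfonyl sulfur gives a 2.9-fold lower number from compound 2 to compound 3 (0.46 log units; beyond the scatter), so a second change at this position also lies beyond the scatter. Diisobutylamino in place of diethylamino gives a 6.0-fold lower number from compound 1 to compound 3 (0.77 log units; beyond the scatter), and across these three compounds more chain carbon on the amine goes with a lower number, with none going against it. No measured evidence accounts for this trend.

Compound 3 brings added chain carbon and branched isobutyl chains in one change, so the compounds shown do not separate the two. As far as these compounds go, whether the trend continues with a longer chain such as dihexylamino, or with a ring amine such as piperidine, on the sulfonyl sulfur remains open.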